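From ethyl to methyl: a one-carbon trim

The compounds below may be only part of what the source reports. "The series", "measured", "known", "first", "only" and "open" are said of these compounds alone.

Measured so far:
compound 1, `Cc1cccc(Nc2nc(-c3ccnc(-c4cnn(C)c4)c3)cs2)c1`, 5200 nM; 5250 nM (2 entries)
compound 2, `CCc1cc(-c2csc(Nc3cccc(C)c3)n2)ccn1`, 6460 nM
compound 3, `Cc1cccc(Nc2nc(-c3ccnc(-c4c(C)noc4C)c3)cs2)c1`, 3000 nM; 3020 nM (2 entries)

Going by the values given here, compound 1 and compound 3 carry other groups where compound 2 has its ethyl, so no single-change step links either of them to compound 2; their values simply stand beside it. Among the compounds with values here, in a functional assay on RCC4 cells (Homo sapiens) for inhibition, read by XTT assay, with a stated time of 4 days (a higher number here means a weaker inhibitor, a lower number a stronger inhibitor), compound 2 gives 6460 nM, the only number among its three entries, the other two having returned no number. Compound 4, `Cc1cccc(Nc2nc(-c3ccnc(C)c3)cs2)c1`, differs from compound 2 by hydrogen in place of methyl on a saturated chain carbon bound to an aromatic carbon. Within the data shown here, no measured step covers this change, and a shift within the usual scatter is expected, if anything toward a weaker inhibitor. Compound 4 is therefore estimated at 8000 nM, between 3000 nM and 20000 nM, the expected step being a 1.2-fold higher number from compound 2 to compound 4 (0.09 log units; within the scatter).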

Compound 4, half-maximal inhibitory concentration: 28800 nM
The estimate for compound 4 lay 3.6-fold (0.56 log units) below the measured number; the whole stated range lies below it.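

In this assay the trim gives a 4.5-fold higher number from compound 2 to compound 4 (0.65 log units; beyond the scatter), so this saturated chain carbon bound to an aromatic carbon responds to the loss of one methyl, which compound 1 and compound 3 alone could not show. Repeat entries in this assay lie close together, so a step of this size stands clear of them: the several entries of compound 1 in this assay, 5200 nM; 5250 nM (2 entries)

As far as these compounds go, whether a longer chain such as propyl would extend the trend remains open. So does what an amine at this place would give.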